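The source may hold more compounds than are shown below. What is called first, only, known or untested is meant among the compounds shown, and "the series" means these compounds.

Compound 1 `COc1ccc(N2C(=O)NC3(CSC4=C3C(=O)c3ncccc3C4=O)C2=O)cc1` gives 70 nM in a functional assay on MT4 cells (Homo sapiens) for antiproliferative activity, read by MTT assay, with a stated time of 96 h; on this read-out lower numbers stand for stronger inhibition and higher numbers for weaker inhibition.
Compound 2 `O=C1NC(=O)C2(CSC3=C2C(=O)c2ncccc2C3=O)N1` gives 130 nM; 120 nM; 130 nM (3 entries) in this assay.
Compound 3 `O=C1C2=C(C(=O)c3ncccc31)C1(CS2)NC(=O)N(c2ccc(Cl)cc2)C1=O` gives 10 nM in this assay.

Compound 3 stands lowest of the two single numbers here; compound 1 is its nearest neighbour, and the step between them, a 7.0-fold lower number from compound 1 to compound 3 (0.85 log units; beyond the scatter), lies beyond the scatter. Compound 2 has several entries rather than one number, (the several entries of compound 2 in this assay, 130 nM; 120 nM; 130 nM (3 entries)), and these show how closely repeats of this assay agree. Compound 4 `CCc1ccc(N2C(=O)NC3(CSC4=C3C(=O)c3ncccc3C4=O)C2=O)cc1` differs from compound 3 by ethyl in place of chloro on an aromatic carbon. Within the data shown here, no measured step exchanges chloro for ethyl, so the only bearing comes from a 7.0-fold lower number from compound 1 to compound 3 (0.85 log units; beyond the scatter), which shows that the group at this position can shift the number in this assay by a modest amount. A small rise in number is therefore expected, a 2.0-fold higher number from compound 3 to compound 4 (0.30 log units; within the scatter). Compound 4 is estimated at 20 nM, with a range from 7 nM to 60 nM.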

Compound 4, half-maximal inhibitory concentration: 1 nM
Estimate against measurement, compound 4: 20-fold (1.30 log units) above, outside the stated range (below it).
By their numbers in this assay, from the lowest: compound 4; then compound 3; then compound 1.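

Exchanging chloro for ethyl gives a 10-fold lower number from compound 3 to compound 4 (1.00 log units; beyond the scatter), so this place on the aromatic ring still had room to move after chloro, and a group without any halogen carries the lowest number of the series. Across the groups shown, the span reaches a 70-fold lower number from compound 1 to compound 4 (1.85 log units; beyond the scatter), a large step from a single exchange in this assay. Repeat entries in this assay sit close together: the several entries of compound 2 in this assay, 130 nM; 120 nM; 130 nM (3 entries).

As far as these compounds go, whether a longer chain such as propyl lowers the number further stays open. So does what an amine or a carboxylic acid would do at this place.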